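This account rests on a few compounds, and the source may have more. Where it says the series, first, only, none or still open, it means among the compounds named here.

Compound 1 `Nc1cc(N)c2nc(-c3ccccc3)c(Sc3ccc(F)cc3)nc2c1` is one of three compounds with results in a functional assay on UACC-62 cells (Homo sapiens) for inhibition, read by sulforhodamine B assay, with a stated time of 48 h; on this read-out higher numbers stand for lower toxicity in this test and lower numbers for higher toxicity in this test. In this assay compound 1 gives 60300 nM, the highest of the three numbers. Compound 3 `CCOC(=O)[C@H](CCC(=O)O)NC(=O)c1ccc(Oc2nc3cc(N)cc(N)c3nc2-c2ccccc2)cc1` gives 58900 nM, which lies within the scatter of the value of compound 1. Compound 2 `COc1cc(CNc2nc3cc(N)cc(N)c3nc2-c2ccccc2)cc(OC)c1OC` gives 29500 nM, a lower number that falls beyond the scatter. Compound 4 `Nc1cc(N)c2nc(-c3ccccc3)c(NCc3ccc(F)cc3)nc2c1` has not yet been measured. It differs from compound 1 in a single place: (4-fluorobenzyl)amino in place of (4-fluorophenyl)sulfanyl on an aromatic carbon. For the measured compounds named here, no pair of measured compounds isolates this change, so the expectation rests on the spread of the three values alone. The step of a 1.6-fold lower number from compound 1 to compound 4 (0.20 log units; within the scatter) is expected to be small, toward a lower number if anything, or none beyond the scatter. For compound 4 the estimated value is 38000 nM, with a range from 15000 nM to 90000 nM.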

Compound 4, concentration lethal to 50% of the cells: 56200 nM
For compound 4 the middle estimate is 1.5-fold (0.17 log units) below the measured one, within the range that was stated.
By their numbers in this assay, from the lowest: compounds 2, 4, 3 and 1 (each within the scatter of the next, the first and the last beyond it).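

In this assay, (4-fluorobenzyl)amino in place of (4-fluorophenyl)sulfanyl gives a 1.1-fold lower number from compound 1 to compound 4 (0.03 log units; within the scatter). This first one-place comparison shows that, on this aromatic carbon, the exchange leaves the number unchanged within the scatter, even though the entering group carries a hydrogen-bond donor that the leaving group lacks. Nothing measured here explains this result.

The compounds shown leave open whether a plain amine, a carboxylic acid or a longer chain on this carbon would also stay within the scatter. They also leave open what the fluorine contributes.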